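A tert-butyl aryl group replaces the amino-methoxy aryl

The source may hold more compounds than are shown below. What is called first, only, known or untested is meant among the compounds shown, and "the series" means these compounds.

In a functional assay on B16-F0 cells (Mus musculus) for inhibition, read by CCK-8 assay, with a stated time of 48 h (a higher number here means a weaker inhibitor, a lower number a stronger inhibitor), compound 1 (`COc1cc(-c2ccnc3cc(-c4c[nH]c5ccccc45)nn23)cc(OC)c1OC`) gives 40 nM. Compound 2 (`COc1ccc(-c2cc3nccc(-c4cc(OC)c(OC)c(OC)c4)n3n2)cc1N`) gives 88 nM, the higher of the two numbers, which makes it the weaker inhibitor of the pair.

Compound 3 (`COc1cc(-c2ccnc3cc(-c4ccc(C(C)(C)C)cc4)nn23)cc(OC)c1OC`) carries 4-(tert-butyl)phenyl in place of the 3-amino-4-methoxyphenyl of compound 2, on an aromatic carbon of a five-membered aromatic ring with 2 nitrogen: 4-(tert-butyl)phenyl in place of 3-amino-4-methoxyphenyl on an aromatic carbon.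

For the measured compounds named here, only one measured step bears on this change. It exchanged 1H-indol-3-yl for the same 3-amino-4-methoxyphenyl group on an aromatic carbon, and it was modest but beyond the scatter: a 2.2-fold higher number from compound 1 to compound 2 (0.34 log units; beyond the scatter). Going by the values given here, no measured compound carries 4-(tert-butyl)phenyl, so neither the size nor the direction of the next step is well fixed. A somewhat larger step than that one is expected, towards a higher number and thus a weaker inhibitor in this assay. The estimated step is a 2.3-fold higher number from compound 2 to compound 3 (0.36 log units; beyond the scatter). For compound 3 the estimate is 200 nM, with an expected range from 50 nM to 1000 nM.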

Compound 3, half-maximal inhibitory concentration: > 10000 nM
Compound 3: a limit, no number; the forecaster's own chance of this, stated with the estimate: 5%; at least 50-fold (1.69 log units) between middle value and limit.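

The reading for compound 3 in this assay is a limit of the assay and not a number: the limit of > 10000 nM in this assay, at which 1 of the 3 values shown sits.

For the compounds shown here, measured against the earlier compounds, 4-(tert-butyl)phenyl gives an at least 110-fold higher number from compound 2 to compound 3 (2.05 log units; beyond the scatter) and an at least 250-fold higher number from compound 1 to compound 3 (2.39 log units; beyond the scatter), so this aromatic carbon of the five-membered aromatic ring with 2 nitrogen does not accept every aryl group, although the step between 1H-indol-3-yl and 3-amino-4-methoxyphenyl was only modest. The change is also far from neutral: each group has one six-membered aromatic ring of carbon only, and the count falls from 1 hydrogen-bond donor and 2 hydrogen-bond acceptors to 0 of each.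

The compounds shown leave open whether the loss comes from the tert-butyl group itself or from the absence of the amino and methoxy groups, since compound 3 differs from compound 2 in all of these at once. As far as these compounds go, how an unsubstituted phenyl, a 4-methoxyphenyl or a 3-aminophenyl would read at this carbon remains unknown, and those groups would be needed to separate the two readings.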